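A few compounds are considered here, and "the series" means these few. Any claim that something is new, unique, unknown or untested is made for them only; others in the source may bear on it.

Measured compounds:
Compound 1, `CC1CCN(C2CCN(S(=O)(=O)c3cccc(Br)c3)CC2)CC1`, gives > 5000 nM in an ADME assay on HCT-116 cells (Homo sapiens) for cytotoxicity, read by CellTiter-Glo, with a stated time of 72 h (a higher number here means a weaker inhibitor, a lower number a stronger inhibitor), which is a limit of the assay and not a number.
Compound 2, `CC1CCN(C2CCN(S(=O)(=O)c3cn(C)cn3)CC2)CC1`, gives > 10000 nM in this assay, again a limit.
Compound 3, `Cc1ccc(-c2cccc(S(=O)(=O)N3CCC(N4CCC(C)CC4)CC3)c2)cc1`, gives > 5000 nM in this assay, also a limit.

Among the compounds with values here, compound 1 thus stands at a limit, and the two further values shown are limits as well, so no compound here has a readable number. Compound 4, `COc1ccc(Br)cc1S(=O)(=O)N1CCC(N2CCC(C)CC2)CC1`, has not yet been measured in this assay. Its difference from compound 1 is methoxy in place of hydrogen on an aromatic carbon. Two measured steps start from compound 1: a step that the two limits leave unreadable from compound 1 to compound 2 and a step that the two limits leave unreadable from compound 1 to compound 3. Neither step gives a readable size, since both ends sit at limits, as summarised by the limit of > 5000 nM in this assay, at which 2 of the 3 values shown sit, and (the limit of > 10000 nM in this assay, at which 1 of the 3 values shown sits). Within the data shown here, no measured step therefore speaks to the size or direction of the change to compound 4, and with every value at a limit the expectation is that compound 4 again shows no readable inhibition rather than any step beyond the scatter. The estimate for compound 4 is 10000 nM, with a range from 3000 nM to 30000 nM. The step that this estimate means is expected to be a step that the limit leaves unreadable from compound 1 to compound 4.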

Compound 4, half-maximal inhibitory concentration: > 5000 nM
Compound 4 ended at the assay's limit (the forecaster's own chance of this, stated with the estimate: 85%); the middle value does not contradict the limit.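

Within the data shown here, compound 1 and compound 4 both stand at a limit of this assay, so no step between them can be read. The compounds shown leave open whether methoxy in place of hydrogen on an aromatic carbon changes cytotoxicity at all, as all four values are limits.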